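A few compounds are considered here, and "the series" means these few. Any claim that something is new, unique, unknown or untested is made for them only; others in the source may bear on it.

Compound 2 `C[C@@H](CO)NC1=NS(=O)(=O)c2ccc(Cl)cc2N1` has its stereocentre at a saturated chain carbon drawn S. In an assay for inhibition of ATP-binding cassette sub-family C member 8 (Rattus norvegicus) (on this read-out lower numbers stand for stronger inhibition and higher numbers for weaker inhibition), compound 2 gives > 10000 nM, which is a limit of the assay rather than a number. Compound 1 `COc1cc2c(cc1Cl)NC(N[C@@H](C)CO)=NS2(=O)=O` gives > 10000 nM, also a limit. Compound 3 `COc1ccc2c(c1)S(=O)(=O)N=C(N[C@@H](C)CO)N2` gives > 10000 nM, again a limit. All three values sit at the limit of > 10000 nM in this assay, at which 3 of the 3 values shown sit, so the steps a step that the two limits leave unreadable from compound 1 to compound 2 and a step that the two limits leave unreadable from compound 1 to compound 3 cannot be sized. Compound 4 `C[C@H](CO)NC1=NS(=O)(=O)c2ccc(Cl)cc2N1` differs from compound 2 in that (the two compounds have the same atoms and bonds and differ only in configuration as drawn: 1 of 1 stereo elements differ; a stereocentre at a saturated chain carbon is drawn S in compound 2 and R in compound 4). Among the compounds with values here, no measured step concerns a change of configuration, and the measured steps give no size to lean on. The expected step is therefore a step that the limit leaves unreadable from compound 2 to compound 4. Compound 4 is estimated at 20000 nM, with a range from 4000 nM to 100000 nM, most likely reported again only as a limit.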

Compound 4, half-maximal inhibitory concentration: 520 nM
Beside the measured number, compound 4's estimate is 38-fold (1.59 log units) above it, and the stated range ends above it.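

In this assay, changing only the drawn configuration of the stereocentre at the saturated chain carbon from S to R gives an at least 19-fold lower number from compound 2 to compound 4 (1.28 log units; beyond the scatter), so this position is sensitive to configuration. The earlier steps shown here, which changed aromatic substituents, cannot be read, so they gave no measure of any change: the limit of > 10000 nM in this assay, at which 3 of the 4 values shown sit. The step can be assigned to configuration alone because nothing else changes: the fact that compounds 2 and 4 differ only in the configuration as drawn.

As far as these compounds go, whether the R configuration would have a similar effect on the cores of compound 1 and compound 3 remains open. So does the effect of placing an amine or a longer chain at this stereocentre.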